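Solubility of the Dimethylimidazolyl Analogue of Compound 1

The source may report more compounds than this note shows. Statements on the series, on what has been measured and on what is new or still open speak of the compounds shown alone.

Measured compounds:
compound 1 `Cc1nccn1-c1cnc(NCc2c(F)ccc3c2CCO3)c2cn[nH]c(=O)c12`: 7000 nM
compound 2 `O=C(Nc1ccccc1)c1cnc(NCc2c(F)ccc3c2CCO3)n2cnnc12`: < 1000 nM
compound 3 `O=C(Nc1cnc(NCc2c(F)ccc3c2CCO3)n2cnnc12)c1ccccc1`: 2000 nM

Of the compounds shown here, three have been measured in a physicochemical assay for solubility, read by LC-MS, in phosphate buffer, with a stated time of 24 h, at pH 7.4; a lower number here means a less soluble compound, a higher number a more soluble compound. Compound 1 gives 7000 nM, the highest of the two numbers obtained. Compound 3, the nearest of them, gives 2000 nM, a number lower than that of compound 1 by more than the usual scatter. Compound 2 is reported only as a limit, sitting at the limit of < 1000 nM in this assay, at which 1 of the 3 values shown sits. Within the data shown here, the one step between compounds that differ in a single place is an at least 2.0-fold higher number from compound 2 to compound 3 (0.30 log units; that floor lies within the scatter); its floor lies within the scatter, and it concerns a core that compound 1 does not share.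

Compound 4 `Cc1ncc(-c2cnc(NCc3c(F)ccc4c3CCO4)c3cn[nH]c(=O)c23)n1C` is the unmeasured analogue of compound 1, with the change (1,2-dimethyl-1H-imidazol-5-yl in place of 2-methyl-1H-imidazol-1-yl on an aromatic carbon). Among the measured compounds shown here, no measured step follows this change, and the only measured step, from compound 2 to compound 3, concerns a different group on a different core, so it gives no guidance on size or direction. In the absence of any bearing step, compound 4 is expected to stay near compound 1, with a step of a 1.2-fold lower number from compound 1 to compound 4 (0.07 log units; within the scatter) in this assay that does not go beyond the scatter. The estimate for compound 4 in this assay is therefore 6000 nM, within a range of 2000 nM to 18000 nM.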

Compound 4, solubility: 15000 nM
Compound 4: the middle estimate sits 2.5-fold (0.40 log units) below what was measured; the measured number falls inside the stated range.
By their numbers in this assay, from the lowest: compound 3; then compound 1; then compound 4. At a limit, below all of these: compound 2.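

In this assay, replacing 2-methyl-1H-imidazol-1-yl with 1,2-dimethyl-1H-imidazol-5-yl on this aromatic carbon gives a 2.1-fold higher number from compound 1 to compound 4 (0.33 log units; beyond the scatter). Among these compounds, this is the first step on the core of compound 1 and the first whose size is printed as beyond the scatter, whereas the earlier step on another core had a floor within it. Both groups hold one five-membered aromatic ring with 2 hetero atoms and have the same donor and acceptor counts, so the number can shift at this place even when those counts stay equal, with the entering group holding 7 heavy atoms against 6; nothing among the measurements shown accounts for this shift.

This single step changes the group as a whole, so it leaves open how much of the shift belongs to the added methyl and how much to the different way the ring is joined to the core. It also leaves open how the number would respond at this place to quite different groups, such as a morpholine, a primary amine or a carboxylic acid.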